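This account rests on a few compounds, and the source may have more. Where it says the series, first, only, none or still open, it means among the compounds named here.

Working notes on the triazole series. Two members share the same core and differ only in the group on the saturated chain carbon bound to the aromatic carbon. Compound 1 `CC(C)CCc1cn(-c2ccc(NC(=O)Nc3cccc(F)c3)cc2)nn1` in an assay for inhibition of ATP-dependent RNA helicase DDX3X (Homo sapiens), read by FRET, with a stated time of 40 min, in the presence of a further agent that is not named here (a lower number here means a stronger inhibitor, a higher number a weaker inhibitor), gives 200 nM. Among the compounds with values here, compound 2 `CCOCc1cn(-c2ccc(NC(=O)Nc3cccc(F)c3)cc2)nn1` in this assay gives 21200 nM, the highest of the two numbers; its nearest neighbour is compound 1, and the single measured step, a 110-fold higher number from compound 1 to compound 2 (2.03 log units; beyond the scatter), is large and beyond the scatter. Compound 3 `CC(=O)CCc1cn(-c2ccc(NC(=O)Nc3cccc(F)c3)cc2)nn1` is not yet measured. The change is 2-oxopropyl in place of ethoxy on a saturated chain carbon bound to an aromatic carbon. Within the data shown here, only the step from compound 1 to compound 2 bears on it: compound 3 moves back towards the chain count of compound 1 while keeping one hydrogen-bond acceptor, so a lower number than compound 2 is expected, by less than a 110-fold higher number from compound 1 to compound 2 (2.03 log units; beyond the scatter). Compound 3 is estimated at 5000 nM, range 1000 nM to 25000 nM. The expected step is a 4.2-fold lower number from compound 2 to compound 3 (0.63 log units; beyond the scatter).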

Compound 3, half-maximal inhibitory concentration: 2400 nM
Estimate against measurement, compound 3: 2.1-fold (0.32 log units) above, within the range that was stated.
By their numbers in this assay, from the lowest: compound 1; then compound 3; then compound 2.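

Ethoxy and 2-oxopropyl hold one hydrogen-bond acceptor each, yet the exchange gives an 8.8-fold lower number from compound 2 to compound 3 (0.95 log units; beyond the scatter) and so the acceptor count alone does not set the number at this position. Acetyl in place of isopropyl still gives a 12-fold higher number from compound 1 to compound 3 (1.08 log units; beyond the scatter) and so compound 3 recovers only part of the large loss seen with compound 2, while compound 1 keeps the lowest number of the three. No measurement at hand accounts for either step.

Still open, on these data alone, is whether an amine, a carboxylic acid or a longer chain on this saturated chain carbon would bring the number closer to that of compound 1. Also open, as far as these compounds go, is whether the order of these three groups would hold on any other core.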